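A Nitrophenyl Swap on the Sulfur Chain

The source may hold more compounds than are shown below. What is called first, only, known or untested is meant among the compounds shown, and "the series" means these compounds.

Compound 1 `Cc1cc(N2CC[C@@H](C)[C@@H](N(C)c3ncnc4[nH]ccc34)C2)n2nc(SCc3ccccc3)nc2n1`: 14400 nM
Compound 2 `Cc1cc(N2CC[C@@H](C)[C@@H](N(C)c3ncnc4[nH]ccc34)C2)n2nc(SCc3csc4ccc(Cl)cc34)nc2n1`: > 100000 nM (a limit of the assay, not a number)
Compound 3 `C=CCSc1nc2nc(C)cc(N3CC[C@@H](C)[C@@H](N(C)c4ncnc5[nH]ccc45)C3)n2n1`: 40900 nM

All three were tested in a functional assay on BGC-823 cells (Homo sapiens) for inhibition, read by MTT assay, with a stated time of 72 h; a higher number here means a weaker inhibitor, a lower number a stronger inhibitor. Compound 3 has the higher of the two exact numbers, so it is the weaker of that pair, while compound 2 has only a limit. Compound 4 `Cc1cc(N2CC[C@@H](C)[C@@H](N(C)c3ncnc4[nH]ccc34)C2)n2nc(SCc3ccc([N+](=O)[O-])cc3)nc2n1` carries 4-nitrophenyl in place of vinyl on a saturated chain carbon bound to a sulfur. Within the data shown here, two measured steps bear on this swap, and they point in opposite directions (a 2.8-fold higher number from compound 1 to compound 3 (0.45 log units; beyond the scatter); an at least 2.4-fold lower number from compound 2 to compound 3 (0.38 log units; beyond the scatter)). Compound 4 keeps a phenyl ring like compound 1, yet the larger aromatic group of compound 2 gave no number. No step beyond the scatter is therefore expected in this assay. The estimated step is (a 1.6-fold lower number from compound 3 to compound 4 (0.21 log units; within the scatter)). The expected value for compound 4 is 25000 nM (estimated range 7000 nM to 90000 nM).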

Compound 4, half-maximal inhibitory concentration: 59600 nM
Compound 4: middle estimate off by 2.4-fold (0.38 log units), on the low side, within the range that was stated.
By their numbers in this assay, from the lowest: compound 1; then compounds 3 and 4 (each within the scatter of the next). At a limit, above all of these: compound 2.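

Placing nitro on the phenyl ring of compound 1 weakens it in this assay, with a 4.1-fold higher number from compound 1 to compound 4 (0.62 log units; beyond the scatter), so this ring is sensitive to a change at its outer end. Exchanging vinyl for 4-nitrophenyl gives a 1.5-fold higher number from compound 3 to compound 4 (0.16 log units; within the scatter), so having a phenyl ring on this chain carbon does not by itself restore the number of compound 1. Compound 2 has only a limit, > 100000 nM, so an at least 1.6-fold lower number from compound 2 to compound 4 (0.22 log units; that floor lies within the scatter) is a floor and gives no exact size.

Going by these compounds, an amine or a carboxylic acid in place of the nitro remains open. So does a longer chain on the sulfur.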